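The source may hold more compounds than are shown below. What is called first, only, known or untested is meant among the compounds shown, and "the series" means these compounds.

Going by the values given here, compound 2, `CCC(=O)N1CC2CC(C1)N2`, is the stronger of the two compounds measured so far: in an assay on CHO cells for displacement of a labelled ligand from Neuronal acetylcholine receptor; alpha3/alpha6/beta2/beta3 (Homo sapiens), read by scintillation counting (a lower number here means a stronger inhibitor, a higher number a weaker inhibitor), compound 2 gives 190 nM. Among the compounds with values here, the only other measured compound, compound 1, `O=C(C1CC1)N1CC2CC1CN2`, differs from compound 2 in more than one place, so the two cannot be read as a single step; in this assay compound 1 gives 10000 nM, a number well beyond the scatter from that of compound 2. Compound 3, `CC(C)C(=O)N1CC2CC(C1)N2`, is the untested compound of interest here. It is reached from compound 2 by a single change: methyl in place of hydrogen on a saturated chain carbon bound to a carbonyl carbon and a saturated chain carbon. Within the data shown here, no step between measured compounds tells how a methyl added at this place on the acyl chain bears on this assay, so the direction of the step is open. A small, branch-building change on a short acyl group would be expected to move the inhibition constant only modestly, and the step from compound 2 to compound 3 is estimated at a 2.1-fold higher number from compound 2 to compound 3 (0.32 log units; beyond the scatter), leaning toward a slight weakening rather than a gain. For compound 3 the inhibition constant in this assay is therefore estimated at 400 nM, with a range from 120 nM to 1500 nM.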

Compound 3, inhibition constant: 580 nM
For compound 3 the middle estimate is 1.5-fold (0.16 log units) below the measured one; measured number inside the range.
By their numbers in this assay, from the lowest: compound 2; then compound 3; then compound 1.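

Going by these compounds alone, the added methyl gives the first reading of this place on the acyl chain. In this assay, the change from ethyl to isopropyl gives a 3.1-fold higher number from compound 2 to compound 3 (0.48 log units; beyond the scatter), so for this pair the branch weakens binding by a modest step, and the direction left open before is now settled. The data offer no explanation for this loss, and nothing given here bears on its cause.

One pair cannot show whether the loss comes from the added carbon itself or from branching on a saturated chain carbon bound to a carbonyl carbon, and a straight propyl chain or a tert-butyl group at the same place would separate these two readings. The compounds shown also leave open how a polar substituent, such as a hydroxyl group or an amine, would compare with methyl on this carbon, and whether any replacement here could match or improve on the unbranched acyl group.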